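The compounds below may be only part of what the source reports. "The series", "measured", "known", "first", "only" and "open" are said of these compounds alone.

In a functional assay (muscle tissue) with Cavia porcellus as the target (a lower number here means that less compound is needed, a higher number that more compound is needed for the effect), compound 3 `COC(=O)C1=C(C)N=C(C)/C(=C(\O)OC)C1c1ccccc1C#N` gives 15.9 nM, the lowest of the three measured numbers, with compound 1 `COC(=O)C1=C(C)N=C(C)/C(=C(\O)OC)C1c1cc(Cl)cc(Cl)c1` at 93.3 nM and compound 2 `COC(=O)C1=C(C)N=C(C)/C(=C(\O)OC)C1c1cccc(O)c1` at 1000 nM. Compound 4 `COC(=O)C1=C(C)N=C(C)/C(=C(\O)OC)C1c1ccccc1F` keeps the shared core but carries fluoro in place of cyano on an aromatic carbon, ortho to a large group: fluoro in place of cyano on an aromatic carbon. For the measured compounds named here, no measured step makes this exact swap. The closest evidence is a 5.9-fold lower number from compound 1 to compound 3 (0.77 log units; beyond the scatter) and a 63-fold lower number from compound 2 to compound 3 (1.80 log units; beyond the scatter), both large enough to show that changes on the phenyl group can move the number well beyond the scatter. No measured number lies lower than that of compound 3 at 15.9 nM, so a modest step upward is expected. The expected step is a 3.1-fold higher number from compound 3 to compound 4 (0.50 log units; beyond the scatter). Compound 4 is estimated at 50 nM, with an expected range from 15 nM to 170 nM.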

Compound 4, half-maximal effective concentration: 42.7 nM
Compound 4: middle estimate off by 1.2-fold (0.07 log units), on the high side, within the range that was stated.
By their numbers in this assay, from the lowest: compound 3; then compound 4; then compound 1; then compound 2.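

With fluoro in place of cyano at this place, this assay shows a 2.7-fold higher number from compound 3 to compound 4 (0.43 log units; beyond the scatter), so the nitrile is not required for a low number. Fluoro also keeps the number under those of the other two phenyl groups, with a 2.2-fold lower number from compound 1 to compound 4 (0.34 log units; beyond the scatter) and a 23-fold lower number from compound 2 to compound 4 (1.37 log units; beyond the scatter), leaving the two compounds substituted at this place, compound 3 and compound 4, lowest of the four. Nothing at hand bears on the reason for these steps. Going by these compounds, what an amine or a methoxy group on this aromatic carbon would give remains open.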